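This account rests on a few compounds, and the source may have more. Where it says the series, first, only, none or still open, it means among the compounds named here.

Of the compounds shown here, three sharing one core have been tested in a functional assay on MDA-MB-435 cells (Homo sapiens) for inhibition, read by sulforhodamine B assay, with a stated time of 48 h; on this read-out lower numbers stand for stronger inhibition of growth and higher numbers for weaker inhibition of growth. Compound 1 (`Cc1nnc(-c2nn(-c3ccccc3)c(-c3ccccc3)c2C#N)c2cn(-c3ccccc3)nc12`) gives > 100000 nM, which is a limit and not a number. For the measured compounds named here, compound 2 (`N#Cc1c(-c2nnc(O)c3nn(-c4ccccc4)cc23)nn(-c2ccccc2)c1-c1ccccc1`) gives 21800 nM, the only true number so far. Compound 3 (`N#Cc1c(-c2nnc(O)c3nn(-c4ccc(Cl)cc4)cc23)nn(-c2ccccc2)c1-c1ccccc1`) gives > 100000 nM, which is again a limit and not a number. Compound 3 therefore stands at the limit of > 100000 nM in this assay, at which 2 of the 3 values shown sit.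

Compound 4 (`N#Cc1c(-c2nnc(-c3ccccc3)c3nn(-c4ccc(Cl)cc4)cc23)nn(-c2ccccc2)c1-c1ccccc1`) differs from compound 3 as follows: phenyl in place of hydroxy on an aromatic carbon. In short, phenyl takes the place of hydroxy on an aromatic carbon, while the chloro group stays.

Going by the values given here, two measured steps bear on this change. Hydroxy in place of methyl at this same carbon gave an at least 4.5-fold lower number from compound 1 to compound 2 (0.66 log units; beyond the scatter). Chloro in place of hydrogen gave an at least 4.5-fold higher number from compound 2 to compound 3 (0.66 log units; beyond the scatter). Going by these compounds, both steps touch a limit, so their true sizes are unknown. Among the compounds with values here, compound 4 gives up the hydroxy group, which was part of the one change that lowered the number, and it keeps the chloro group, which was part of the change that raised it. Within the data shown here, no tested compound carries phenyl at this carbon, so the forecast is uncertain.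

The estimated change is an at least 1.1-fold lower number from compound 3 to compound 4 (0.04 log units; that floor lies within the scatter), so no step beyond the scatter is expected in this assay. Compound 4 is expected to read about 90000 nM, within an estimated range from 20000 nM to 100000 nM.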

Compound 4, concentration for 50% growth inhibition: 23800 nM
Estimate against measurement, compound 4: 3.8-fold (0.58 log units) above; the range from low to high includes it.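

In this assay compound 3 gives > 100000 nM, which is a limit and not a number. Phenyl in place of hydroxy on this aromatic carbon gives an at least 4.2-fold lower number from compound 3 to compound 4 (0.62 log units; beyond the scatter), so a hydroxy group, with its hydrogen-bond donor and acceptor, is not required here for a measurable value, at least while the chloro group stays in place; until now, hydroxy was the only group at this carbon that had given a true number, and the chloro group had appeared only in a compound stuck at the limit. The real size of this gain cannot be stated, because the starting point is a limit: the limit of > 100000 nM in this assay, at which 2 of the 4 values shown sit.

The compounds shown leave open whether phenyl at this carbon would give a similar value with hydrogen in place of the chloro group, which would separate the effect of the phenyl group from that of the chloro group. They also leave open how an amine, a methoxy group or a longer chain at this same carbon would read in this assay.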